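Chloro in place of hydrogen on a purine-like core

The compounds below may be only part of what the source reports. "The series", "measured", "known", "first", "only" and "open" are said of these compounds alone.

Of the compounds shown here, three that share one side chain have been measured in a functional assay on MDA-MB-435 cells (Homo sapiens) for cytotoxicity, read by sulforhodamine B assay, with a stated time of 48 h; a higher number here means a weaker inhibitor of growth, a lower number a stronger inhibitor of growth. Compound 1, `ClCc1ccccc1Cn1cnc2c(Cl)nc(Cl)nc21`, gives 1620 nM in this assay. Compound 2, `ClCc1ccccc1Cn1cnc2c(Cl)ncnc21`, gives 3020 nM. Compound 3, `ClCc1ccccc1Cn1cnc2ncnc(Cl)c21`, gives 1940 nM; its nearest neighbour among the three is compound 1 and its furthest is compound 2, and both of those gaps lie within the scatter. Compound 2 and compound 3 are built from the same atoms joined differently, and the difference between the two cores is not broken down here.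

Between compound 2 and compound 1 a single change is made: chloro in place of hydrogen on an aromatic carbon. This gave a 1.9-fold lower number from compound 2 to compound 1 (0.27 log units; within the scatter). The same change, applied to the core of compound 3, leads to compound 4, `ClCc1ccccc1Cn1cnc2nc(Cl)nc(Cl)c21`, which has not yet been measured in this assay. Here the change is chloro in place of hydrogen on an aromatic carbon, and the surroundings of the place are the same word for word as in the earlier pair. Among the four compounds this change occurs twice in all.

Compound 4 is expected to show a step of a 1.9-fold lower number from compound 3 to compound 4 (0.29 log units; within the scatter), a size that rests on the earlier step of a 1.9-fold lower number from compound 2 to compound 1 (0.27 log units; within the scatter), which itself lay within the scatter. On that basis compound 4 is estimated at 1000 nM in this assay, with a range expected from 400 nM to 2500 nM.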

Compound 4, concentration for 50% growth inhibition: 16600 nM
The estimate for compound 4 lay 17-fold (1.22 log units) below the measured number; measured number outside the range, above it.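

In this assay, chloro in place of hydrogen on an aromatic carbon gave an 8.6-fold higher number from compound 3 to compound 4 (0.93 log units; beyond the scatter) and so did not repeat on the core of compound 3 what it had done on the core of compound 2, where the step stayed within the scatter; the two steps differ: the same change on two cores in this assay, a 1.9-fold lower number (0.27 log units; within the scatter) from compound 2 to compound 1 and an 8.6-fold higher number (0.93 log units; beyond the scatter) from compound 3 to compound 4, 16-fold (1.20 log units) apart, beyond the scatter of two such steps.

This shows that, for these two cores, a step measured on one could not be carried to the other, even though the change itself is the same and the shared side chain is unchanged. For the compounds shown here, it does not show why the cores part, nor does it set a rule for the series, since the comparison rests on only two pairs, and one of those steps is too small to give a firm direction.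

The compounds shown leave open whether an amine or a methoxy group, placed where this chloro sits between two ring nitrogen atoms, would also give different steps on the two cores. They also leave open whether the gap between the two steps would persist if a longer chain took the place of the chloromethyl group on the side chain.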